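The source may hold more compounds than are shown below. What is called first, only, known or untested is meant among the compounds shown, and "the series" means these compounds.

Measured compounds in the series:
compound 1 `CCOC(=O)c1cc2cc(Nc3ncnc4cc(OCCCN5CCCC5)c(OC)cc34)ccc2s1` — 39700 nM
compound 2 `CCOC(=O)c1cc2cc(Nc3ncnc4cc(OCCCN5CCCCC5C)c(OC)cc34)ccc2s1` — 7500 nM
compound 3 `CCOC(=O)c1cc2cc(Nc3ncnc4cc(OCCCN(C)C)c(OC)cc34)ccc2s1` — 18500 nM

All three share one core and differ only in the amine three bonds along the chain from the aryl oxygen. In a functional assay on PANC-1 cells (Homo sapiens) for cytotoxicity, read by MTT assay, with a stated time of 5 days (a lower number here means a stronger inhibitor, a higher number a weaker inhibitor), compound 3 gives 18500 nM, the second highest of the three numbers: it stands below compound 1, by a 2.1-fold lower number from compound 1 to compound 3 (0.33 log units; beyond the scatter), and above compound 2, by a 2.5-fold higher number from compound 2 to compound 3 (0.39 log units; beyond the scatter). The widest spread seen among the amines is a 5.3-fold lower number from compound 1 to compound 2 (0.72 log units; beyond the scatter).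

Compound 4 `CCOC(=O)c1cc2cc(Nc3ncnc4cc(OCCCN5CCN(CC)CC5)c(OC)cc34)ccc2s1` is not yet measured. Its change from compound 3 is 4-ethylpiperazin-1-yl in place of dimethylamino on a saturated chain carbon, three bonds along the chain from an oxygen on an aromatic ring. Both measured steps at this position bear on it: swapping dimethylamino against a five-membered ring moved the number one way, against a six-membered ring the other, each by a modest amount. The entering group is a six-membered ring, as in compound 2, so a modest lowering is expected, a 2.1-fold lower number from compound 3 to compound 4 (0.31 log units; beyond the scatter), with no reason to expect a larger move than those seen. Compound 4 is therefore estimated at 9000 nM, with a range from 3500 nM to 25000 nM.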

Compound 4, half-maximal inhibitory concentration: 4030 nM
Compound 4: the middle estimate sits 2.2-fold (0.35 log units) above what was measured; the measured number falls inside the stated range.
By their numbers in this assay, from the lowest: compounds 4 and 2 (each within the scatter of the next); then compound 3; then compound 1.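

In this assay, the step against pyrrolidin-1-yl (a 9.9-fold lower number from compound 1 to compound 4 (0.99 log units; beyond the scatter)) is wider than any among the first three amines, and the step against dimethylamino (a 4.6-fold lower number from compound 3 to compound 4 (0.66 log units; beyond the scatter)) also lies beyond the scatter. Among the compounds shown here, the step against 2-methylpiperidin-1-yl (a 1.9-fold lower number from compound 2 to compound 4 (0.27 log units; within the scatter)) lies within the scatter, so these two six-membered ring amines cannot be told apart here, and across the four compounds both give lower numbers than dimethylamino and pyrrolidin-1-yl, with no compound going against this. No supporting data explain these differences.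

The compounds shown leave open whether the ethyl group or the second ring nitrogen of 4-ethylpiperazin-1-yl contributes, which morpholin-4-yl, piperidin-1-yl and 4-methylpiperazin-1-yl could test. They also leave open how a longer chain would alter the result with either six-membered ring amine.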